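A few compounds are considered here, and "the series" means these few. Any claim that something is new, unique, unknown or untested is made for them only; others in the source may bear on it.

Of the compounds shown here, three sharing one core have been measured in a functional assay on cells (Homo sapiens) for cytotoxicity, read by MTT assay, with a stated time of 24 h (a lower number here means a stronger inhibitor, a higher number a weaker inhibitor), so far: compound 1 (`CCCCCCCCCCCCCCNC(=O)[C@H](CO)/N=C/c1cccc(OC)c1`), compound 2 (`CCCCCCCCCCCCCCNC(=O)[C@H](CO)/N=C/c1ccc(Cl)cc1`) and compound 3 (`CCCCCCCCCCCCCCNC(=O)[C@H](CO)NCc1ccccc1OC`). Compound 1 gives 31300 nM and compound 2 gives 27500 nM in this test, while compound 3 gives 100000 nM as the highest number of the three, which makes it the weakest inhibitor here.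

The next compound is compound 4 (`CCCCCCCCCCCCCCNC(=O)[C@H](CO)/N=C/c1cccc(Cl)c1`). The (2-methoxybenzyl)amino group of compound 3 leaves, and the change reads as a group of 9 heavy atoms (7 carbon, 1 nitrogen, 1 chlorine; one six-membered aromatic ring of carbon only) in place of a group of 10 heavy atoms (8 carbon, 1 nitrogen, 1 oxygen; one six-membered aromatic ring of carbon only), on a saturated chain carbon bound to a carbonyl carbon and a saturated chain carbon in full. Compound 4 thereby regains the carbon with a double bond to nitrogen found in compound 1 and compound 2.

Going by the values given here, two measured steps bear directly on this swap, and both are modest but beyond the scatter: a 3.2-fold higher number from compound 1 to compound 3 (0.50 log units; beyond the scatter) and a 3.6-fold higher number from compound 2 to compound 3 (0.56 log units; beyond the scatter) for the same kind of exchange in the opposite direction. Changing the ring group among the double-bonded compounds made little difference, as a 1.1-fold lower number from compound 1 to compound 2 (0.06 log units; within the scatter) stays within the scatter. Among the compounds with values here, no compound with exactly this ring group has been measured yet, so a modest fall in the number is expected, to about the level of compound 1 and compound 2.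

The expected change is a 3.6-fold lower number from compound 3 to compound 4 (0.55 log units; beyond the scatter) in this assay on this reasoning. The estimate for compound 4 is 28000 nM with an expected range from 15000 nM to 52000 nM in this test.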

Compound 4, half-maximal inhibitory concentration: 24100 nM
Compound 4: the middle estimate sits 1.2-fold (0.07 log units) above what was measured, within the range that was stated.
By their numbers in this assay, from the lowest: compounds 4, 2 and 1 (each within the scatter of the next); then compound 3.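

In this assay, going back to a carbon with a double bond to nitrogen gives a 4.1-fold lower number from compound 3 to compound 4 (0.62 log units; beyond the scatter) and is the clearest gap so far, so compound 3 now stands apart from all three double-bonded compounds. Among those three, the ring group counts for little: 3-chlorophenyl in place of 4-chlorophenyl gives a 1.1-fold lower number from compound 2 to compound 4 (0.06 log units; within the scatter) and stays within the scatter, and chloro in place of methoxy on an aromatic carbon gives a 1.3-fold lower number from compound 1 to compound 4 (0.11 log units; within the scatter) and also stays within it, so chlorine in two ring placings and a methoxy group leave compound 1, compound 2 and compound 4 at one level. Nothing available explains the gap to compound 3 or this flat response to the ring group.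

Going by these compounds, compound 3 differs from compound 4 in both the link and the ring substituent, so the share of the step that belongs to the saturated link alone stays open, and a (3-chlorobenzyl)amino group would separate the two. Also open, on these data alone, is how the level of the double-bonded compounds responds to a hydroxy group on the ring or to a decyl chain on the amide nitrogen.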